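Trading a Selenium Chain for Methylsulfanyl on the Core

The source may hold more compounds than are shown below. What is called first, only, known or untested is meant among the compounds shown, and "the series" means these compounds.

Compounds measured so far:
compound 1, `CCCCC[Se]c1nc(NCc2ccc(SC)cc2)c2ccccc2n1`: 40400 nM
compound 2, `CCCCC[Se]c1nc([Se]CCCCC)c2ccccc2n1`: > 100000 nM (a limit of the assay, not a number)
compound 3, `CCCCC[Se]c1nc(NCc2ccccc2)c2ccccc2n1`: 37700 nM

In a functional assay on HTB-54 cells (Homo sapiens) for cytotoxicity, read by MTT assay, with a stated time of 72 h (a higher number here means a weaker inhibitor of growth, a lower number a stronger inhibitor of growth), compound 3 gives 37700 nM. That is the lower of the two actual numbers, but the step of a 1.1-fold lower number from compound 1 to compound 3 (0.03 log units; within the scatter) lies within the scatter, so compound 3 and compound 1 cannot be told apart. For compound 2 the assay reports only a limit, (the limit of > 100000 nM in this assay, at which 1 of the 3 values shown sits). Among the measured compounds shown here, the step of an at least 2.6-fold lower number from compound 2 to compound 3 (0.42 log units; beyond the scatter) is the one clear change seen.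

Compound 4, `CSc1nc(NCc2ccccc2)c2ccccc2n1`, differs from compound 3 by a group of 2 heavy atoms (1 carbon, 1 sulfur; no ring) in place of a group of 6 heavy atoms (5 carbon, 1 selenium; no ring), on an aromatic carbon. Neither measured step touches that chain: one changes a ring substituent, the other replaces the partner group on the shared core. So no measured step bears directly on this change, and the expectation rests on compound 3 alone. The expected step of a 1.3-fold higher number from compound 3 to compound 4 (0.12 log units; within the scatter) is therefore small, with wide uncertainty either way. Compound 4 is estimated at 50000 nM, between 15000 nM and 160000 nM.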

Compound 4, concentration for 50% growth inhibition: 37900 nM
Compound 4: the middle estimate sits 1.3-fold (0.12 log units) above what was measured, and the stated range covers the measured number.
By their numbers in this assay, from the lowest: compounds 3, 4 and 1 (each within the scatter of the next). At a limit, above all of these: compound 2.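

In this assay, putting methylsulfanyl in place of the chain of 5 carbon and 1 selenium, on the aromatic carbon between two ring nitrogen atoms, gives a 1.0-fold higher number from compound 3 to compound 4 (0.00 log units; within the scatter) and so no detectable change. The earlier steps shown here left this position untouched; this one shows that, with the benzylamino group present, neither the selenium nor the longer chain is needed to keep this level of growth inhibition. Nothing in the data shown explains why the two groups read alike.

Going by these compounds, it remains open whether this position affects the reading at all, which a compound with an amine or a hydrogen here in place of methylsulfanyl could test. On these data alone, it also remains open whether a longer sulfur-linked chain, such as pentylsulfanyl, would read the same as the selenium chain.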